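Hydroxy in place of trifluoromethyl on compound 2

A few compounds are considered here, and "the series" means these few. Any claim that something is new, unique, unknown or untested is made for them only; others in the source may bear on it.

Values in a functional assay on HT-29 cells (Homo sapiens) for inhibition, read by sulforhodamine B assay, with a stated time of 48 h; a lower number here means a stronger inhibitor of growth, a higher number a weaker inhibitor of growth:
- compound 1 `CC1(/C=C/c2ccccc2C(F)(F)F)C=CC(=O)O1`: 15800 nM
- compound 2 `CC1(/C=C/c2ccc(C(F)(F)F)cc2)C=CC(=O)O1`: 12300 nM
- compound 3 `COc1ccc(/C=C/C2(C)C=CC(=O)O2)c(OC)c1OC`: 133000 nM

Compound 2 and compound 1 lie within the scatter of each other, at the low end of the three values. Compound 3 stands beyond the scatter from compound 2, at a higher number.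

The next compound is compound 4 `CC1(/C=C/c2ccc(O)cc2)C=CC(=O)O1`, with hydroxy in place of trifluoromethyl on an aromatic carbon of compound 2 (hydroxy in place of trifluoromethyl on an aromatic carbon). Within the data shown here, no measured pair differs in one place only, so no direct step guides this change in this assay. Among the measured compounds shown here, the only hint is compound 3 at 133000 nM, which carries oxygen-linked methoxy groups on its aromatic ring but differs from compound 2 in more than one place. A rise beyond the scatter, toward weaker growth inhibition and short of the level of compound 3, is therefore expected. The estimated change is a 3.3-fold higher number from compound 2 to compound 4 (0.51 log units; beyond the scatter). For compound 4 the expected value is 40000 nM, with an estimated range of 13000 nM to 120000 nM.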

Compound 4, concentration for total growth inhibition: 122000 nM
Compound 4: middle estimate off by 3.1-fold (0.48 log units), on the low side, and the stated range ends below it.
By their numbers in this assay, from the lowest: compounds 2 and 1 (each within the scatter of the next); then compounds 4 and 3 (each within the scatter of the next).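

In this assay, among these compounds, hydroxy in place of trifluoromethyl on this aromatic carbon, para to a group of 9 heavy atoms, gives a 9.9-fold higher number from compound 2 to compound 4 (1.00 log units; beyond the scatter) and is the only single-place step so far. This position is therefore not indifferent to its substituent: growth inhibition weakens when trifluoromethyl, with 4 heavy atoms and no hydrogen-bond donor, gives way to hydroxy, with 1 heavy atom and 1 hydrogen-bond donor. No measurement shown here explains the size of this step.

A single step cannot separate the loss of trifluoromethyl from the arrival of hydroxy. As far as these compounds go, it also remains open whether an amine or a carboxylic acid on the same carbon would give a value closer to that of compound 2 or of compound 4.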